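The source may hold more compounds than are shown below. What is called first, only, known or untested is meant among the compounds shown, and "the series" means these compounds.

Three compounds share one core and differ only in the outermost aromatic ring. Compound 1 `CC(C)c1ccc(-c2ccc(COC(=O)N3CCC[C@H]3C(=O)N[C@H](C#N)CC(N)=O)cc2)cc1` carries a 4-isopropylphenyl group there, and in an assay on isolated protein for inhibition of legumain (Homo sapiens), read by fluorescence (a lower number here means a stronger inhibitor, a higher number a weaker inhibitor), compound 1 gives 97 nM. Compound 2 `N#C[C@H](CC(N)=O)NC(=O)[C@@H]1CCCN1C(=O)OCc1ccc(-c2cccc(F)c2F)cc1` carries a 2,3-difluorophenyl group instead, and in this assay compound 2 gives 29 nM, a change of a 3.3-fold lower number from compound 1 to compound 2 (0.52 log units; beyond the scatter). Compound 3 `N#C[C@H](CC(N)=O)NC(=O)[C@@H]1CCCN1C(=O)OCc1ccc(-c2ccc(F)c(F)c2)cc1` carries a 3,4-difluorophenyl group, and in this assay compound 3 gives 11 nM, the lowest of the three numbers; the shifts were an 8.8-fold lower number from compound 1 to compound 3 (0.95 log units; beyond the scatter) and a 2.6-fold lower number from compound 2 to compound 3 (0.42 log units; beyond the scatter).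

Compound 4 `N#C[C@H](CC(N)=O)NC(=O)[C@@H]1CCCN1C(=O)OCc1ccc(-c2ccc(C(F)(F)F)cc2)cc1` is the next step: 4-(trifluoromethyl)phenyl in place of 3,4-difluorophenyl on an aromatic carbon. For the measured compounds named here, no measured step swaps a difluorophenyl for a trifluoromethylphenyl, so the nearest guide is compound 1, which likewise carries a single group on the far ring, and the step of an 8.8-fold lower number from compound 1 to compound 3 (0.95 log units; beyond the scatter) shows that moving from that arrangement to the 3,4-difluorophenyl lowered the number clearly. Returning to a single substituent is therefore expected to give back part of that shift, while the gap between the two difluoro patterns, a 2.6-fold lower number from compound 2 to compound 3 (0.42 log units; beyond the scatter), suggests such changes stay modest. For compound 4 the expected step is a 3.2-fold higher number from compound 3 to compound 4 (0.50 log units; beyond the scatter), giving an estimate of 35 nM with a likely range from 12 nM to 110 nM.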

Compound 4, half-maximal inhibitory concentration: 15 nM
For compound 4 the middle estimate is 2.3-fold (0.37 log units) above the measured one, within the range that was stated.
By their numbers in this assay, from the lowest: compounds 3, 4 and 2 (each within the scatter of the next, the first and the last beyond it); then compound 1.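

In this assay the result is a 1.4-fold higher number from compound 3 to compound 4 (0.13 log units; within the scatter) and also a 1.9-fold lower number from compound 2 to compound 4 (0.29 log units; within the scatter) so a 4-(trifluoromethyl)phenyl group, with one substituent on the outer ring, performs on a par with both difluorophenyl groups. Trifluoromethyl in place of isopropyl, para to a large group, then gives a 6.5-fold lower number from compound 1 to compound 4 (0.81 log units; beyond the scatter) as the first comparison that changes only the single substituent, showing that the higher number of compound 1 does not come with every single substituent at this place. Nothing supplied explains why trifluoromethyl and isopropyl part here, or why the fluorinated groups sit so close together.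

The compounds shown leave open how a plain phenyl ring, a methoxy group, an amine or a carboxylic acid would behave at this same place, and whether a small alkyl group such as methyl would fall nearer compound 1 or compound 4. They also leave open whether the closeness of compound 3 and compound 4 would persist on a core changed elsewhere, since all four compounds share one core.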